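This account rests on a few compounds, and the source may have more. Where it says the series, first, only, none or still open, it means among the compounds named here.

Within the data shown here, in an ADME assay on the whole organism (strain Sprague-Dawley) for metabolic stability, with Rattus norvegicus as the target (a lower number here means that the compound disappears faster, a higher number that the compound lasts longer), compound 1 `CN[C@@H](C)c1ccc(N2CC[C@H](NS(=O)(=O)c3ccc4cc(Cl)ccc4c3)C2=O)c(F)c1` gives 18 h, the higher of the two numbers so far. Compound 2 `CN1CCCC1c1ccc(N2CC[C@H](NS(=O)(=O)/C=C/c3ccc(Cl)s3)C2=O)c(F)c1` gives 1.4 h, a gap beyond the scatter. Compound 3 `O=C1[C@@H](NS(=O)(=O)c2ccc3cc(Cl)ccc3c2)CCN1c1ccc([C@H]2CCCN2)cc1F` carries pyrrolidin-2-yl in place of 1-(methylamino)ethyl on an aromatic carbon. Among the measured compounds shown here, no measured pair isolates this change, so the expectation in this assay stays cautious: a small fall, probably not beyond the scatter, with the estimated step being a 1.8-fold lower number from compound 1 to compound 3 (0.26 log units; within the scatter). The estimate for compound 3 is 10 h, with an expected range of 4 h to 22 h.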

Compound 3, half-life: 10.2 h
The estimate for compound 3 lay 1.0-fold (0.01 log units) below the measured number; the measured number falls inside the stated range.
By their numbers in this assay, from the lowest: compound 2; then compounds 3 and 1 (each within the scatter of the next).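

Among these compounds, this is the first single-place pair at this position, on an aromatic carbon para to a large group. In this assay, pyrrolidin-2-yl in place of 1-(methylamino)ethyl gives a 1.8-fold lower number from compound 1 to compound 3 (0.25 log units; within the scatter), so the ring form and the open chain cannot be told apart here. No measurement on hand accounts for this result.

Still open, from the compounds shown here alone, is how a piperidin-2-yl, aminomethyl or hydroxymethyl group would read at this position in this assay. Also open, going by these compounds, is whether the same step holds when the rest of the core of compound 1 is changed.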